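The source may hold more compounds than are shown below. What is called first, only, known or untested is meant among the compounds shown, and "the series" means these compounds.

Compound 1 `Oc1ccc(O)c(-c2cc(-c3ccccc3)nn2-c2ccccc2)c1` is a pair of phenyl rings joined to a dihydroxyphenyl group through a shared core. For the measured compounds named here, in a functional assay on cells (Cancer cell lines, Homo sapiens) for cytotoxicity, read by sulforhodamine B assay, with a stated time of 48 h (a higher number here means a weaker inhibitor of growth, a lower number a stronger inhibitor of growth), compound 1 gives 37700 nM, which is the highest of the two numbers measured so far, and so the weaker of the two inhibitors of growth. Going by the values given here, its nearest neighbour, compound 2 `Oc1ccc(O)c(-c2cc(-c3ccc(Cl)cc3)nn2-c2ccccc2)c1`, gives 8010 nM in this assay, and the one step recorded, a 4.7-fold lower number from compound 1 to compound 2 (0.67 log units; beyond the scatter), came from putting chloro in place of hydrogen on an aromatic carbon. Compound 3 `CC(=O)NS(=O)(=O)c1ccc(-n2nc(-c3ccccc3)cc2-c2cc(O)ccc2O)cc1` differs from compound 1 in another way: acetylsulfamoyl in place of hydrogen on an aromatic carbon. That change sits on a different ring from the chloro of compound 2, so the recorded step is only a loose guide to its size. A modest shift, or none beyond the scatter, is therefore expected, a 1.9-fold lower number from compound 1 to compound 3 (0.28 log units; within the scatter). For compound 3 the estimate in this assay is 20000 nM, within a range of 5000 nM to 60000 nM.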

Compound 3, concentration for 50% growth inhibition: 100000 nM
For compound 3 the middle estimate is 5.0-fold (0.70 log units) below the measured one; the measured number lies above the stated range.
By their numbers in this assay, from the lowest: compound 2; then compound 1; then compound 3.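

In this assay, acetylsulfamoyl on an aromatic carbon, para to a large group, moves the number the opposite way from the chloro change (a 2.7-fold higher number from compound 1 to compound 3 (0.42 log units; beyond the scatter), against a 4.7-fold lower number from compound 1 to compound 2 (0.67 log units; beyond the scatter)). A single substitution on a phenyl ring of compound 1 can therefore weaken growth inhibition as well as strengthen it, so the first step gave no general rule for adding groups to this compound. No measurement shown accounts for the rise.

On these data alone, the two changes differ in both group and ring, so it remains open whether the group or the ring sets the direction, and whether chloro on this ring would also lower the number. A plain sulfamoyl group without the acetyl, or an amine at this place, could help separate these possibilities.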